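The source may report more compounds than this note shows. Statements on the series, on what has been measured and on what is new or still open speak of the compounds shown alone.

Of the compounds shown here, three sharing one core have been measured in a functional assay on PANC-1 cells (Homo sapiens) for inhibition, read by MTT assay, with a stated time of 24 h, tested at 10 uM; a higher number here means more inhibition at the concentration tested (going by the name of the read-out), a lower number less inhibition. Compound 1 `CC(C)=CCC1Cc2c(OCCCNS(=O)(=O)c3ccc(Br)cc3)cc(=O)n(CCCO)c2CC1(C)C` gives 3.7%, compound 2 `COc1ccc(C(=O)NCCCOc2cc(=O)n(CCCO)c3c2CC(CC=C(C)C)C(C)(C)C3)cc1` gives 2.5%, and compound 3 `CC(C)=CCC1Cc2c(OCCCNC(=O)c3cccs3)cc(=O)n(CCCO)c2CC1(C)C` gives 5.6%. Compound 3 sits within the scatter of both others: a number 1.9 percentage points higher from compound 1 to compound 3 (within the scatter) and a number 3.1 percentage points higher from compound 2 to compound 3 (within the scatter), as does a number 1.2 percentage points lower from compound 1 to compound 2 (within the scatter). Compound 4 `CC(C)=CCC1Cc2c(OC(=O)Nc3ccc(F)c(F)c3)cc(=O)n(CCCO)c2CC1(C)C` differs from compound 3 by (3,4-difluorophenyl)carbamoyl in place of 3-(((thiophen-2-yl)carbonyl)amino)propyl on an oxygen on an aromatic ring. Within the data shown here, no measured step touches this position in the same way; the three measured steps only exchange the group on the amine nitrogen and were all within the scatter. With every known change producing no step beyond the scatter, compound 4 is expected to give 5%, between 0% and 16%, so that a number 0.6 percentage points lower from compound 3 to compound 4 (within the scatter) is estimated.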

Compound 4, a percentage reported as inhibition, at one concentration (the size of the read-out at that concentration, not a potency): 0%
The estimate for compound 4 lay 5 percentage points above the measured number; the range from low to high includes it.
By their numbers in this assay, from the lowest: compounds 4, 2, 1 and 3 (each within the scatter of the next).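

Among these compounds, compound 4 gives the first reading at the oxygen on an aromatic ring rather than on the amine nitrogen: (3,4-difluorophenyl)carbamoyl in place of 3-(((thiophen-2-yl)carbonyl)amino)propyl gives a number 5.6 percentage points lower from compound 3 to compound 4 (within the scatter) in this assay. So even this exchange of the whole chain on that oxygen produces no step beyond the scatter, as with the earlier exchanges on the amine nitrogen. No measurement shown explains this result. Going by these compounds, whether an amine, a carboxylic acid or a longer chain on this oxygen would give a step beyond the scatter remains open, as does the effect of an unsubstituted phenylcarbamoyl.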